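Moving a hydroxyl around a hydrazone's aromatic ring

The compounds below may be only part of what the source reports. "The series", "measured", "known", "first", "only" and "open" are said of these compounds alone.

Of the compounds shown here, two have been measured in an ADME assay on MT4 cells (Homo sapiens) for cytotoxicity, read by MTT assay, with a stated time of 4 days; on this read-out lower numbers stand for higher toxicity in this test and higher numbers for lower toxicity in this test. Compound 1, `COc1ccc(/C=N/NC(=O)COc2cccc3ccccc23)cc1OC`, gives 14.7 ug/mL in this assay. Compound 2, `C/C(=N\NC(=O)COc1cccc2ccccc12)c1ccc(O)cc1`, gives 68.8 ug/mL in this assay, the higher of the two numbers and therefore the less toxic of the pair; the gap to compound 1 lies beyond the usual scatter, so compound 2 stands clearly apart as the gentler compound on these cells.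

The next compound, compound 3, `C/C(=N\NC(=O)COc1cccc2ccccc12)c1ccccc1O`, has not yet been measured. It keeps every atom of compound 2 and differs only in how they are joined: 2-hydroxyphenyl in place of 4-hydroxyphenyl on a carbon with a double bond to nitrogen. Going by the values given here, no measured pair in this set shows what such a shift of the hydroxyl does to cytotoxicity, so there is no direct guide.

Lacking that guide, the step of a 1.3-fold lower number from compound 2 to compound 3 (0.10 log units; within the scatter) is expected to be small, with no direction that can be called beyond the scatter. Compound 3 is therefore estimated at 55 ug/mL in this assay, within a range from 25 ug/mL to 110 ug/mL.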

Compound 3, half-maximal cytotoxic concentration: 11.3 ug/mL
For compound 3 the middle estimate is 4.9-fold (0.69 log units) above the measured one; measured number outside the range, below it.
By their numbers in this assay, from the lowest: compounds 3 and 1 (each within the scatter of the next); then compound 2.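

In this assay, the arrangement of atoms on this ring matters: 2-hydroxyphenyl in place of 4-hydroxyphenyl, on a carbon with a double bond to nitrogen, gives a 6.1-fold lower number from compound 2 to compound 3 (0.78 log units; beyond the scatter), and a lower number here stands for higher toxicity on these cells. The milder result for compound 2 therefore cannot be credited simply to having a hydroxyphenyl group at this place, since the same atoms joined differently move the read-out beyond the scatter. No measured information accounts for this shift, so it stands as an observation without an established cause.

Going by these compounds, whether an amine or a carboxylic acid in place of the hydroxyl would show the same split between the two arrangements remains open, as does the question of where a plain phenyl group would fall relative to compound 2 and compound 3. Only toxicity on these cells is shown, so it also remains open whether this change affects any other property of the compounds.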